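The compounds below may be only part of what the source reports. "The series", "measured", "known", "first", "only" and "open" are said of these compounds alone.

Of the compounds shown here, three built on one shared core have been tested in a functional assay on HEK293 cells for agonist activity at melatonin receptor type 1A (Homo sapiens), read by calcium flux; a higher number here means that more compound is needed for the effect, a lower number that less compound is needed. Compound 1 `COc1cc2c(CO)coc2cc1C` gives 700000 nM. Compound 2 `COc1cc2c(CN)coc2cc1C` gives 250000 nM, and compound 3 `COc1cc2c(CN(C)C)coc2cc1C` gives 440000 nM. Compound 3 stands second highest of the three numbers; both a 1.6-fold lower number from compound 1 to compound 3 (0.20 log units; within the scatter) and a 1.8-fold higher number from compound 2 to compound 3 (0.25 log units; within the scatter) lie within the scatter, so no order among them is secure. Compound 4 `COc1cc2c(CN3CCCC3)coc2cc1C` differs from compound 3 in one place: pyrrolidin-1-yl in place of dimethylamino on a saturated chain carbon bound to an aromatic carbon. Within the data shown here, no measured step matches this change directly; the closest, a 1.8-fold higher number from compound 2 to compound 3 (0.25 log units; within the scatter), stayed within the scatter, while a 2.8-fold lower number from compound 1 to compound 2 (0.45 log units; beyond the scatter) was only modest. The step of a 1.1-fold lower number from compound 3 to compound 4 (0.04 log units; within the scatter) is therefore expected to be small, with no clear direction. Compound 4 is estimated at 400000 nM, in a range from 150000 nM to 1000000 nM.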

Compound 4, half-maximal effective concentration: 310000 nM
Compound 4: middle estimate off by 1.3-fold (0.11 log units), on the high side; the measured number falls inside the stated range.
By their numbers in this assay, from the lowest: compounds 2, 4, 3 and 1 (each within the scatter of the next, the first and the last beyond it).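

In this assay, putting pyrrolidin-1-yl in place of dimethylamino on this saturated chain carbon brings a 1.4-fold lower number from compound 3 to compound 4 (0.15 log units; within the scatter) and putting it in place of amino brings a 1.2-fold higher number from compound 2 to compound 4 (0.09 log units; within the scatter) so a five-membered ring here is not told apart from either open amine. In place of hydroxy it brings a 2.3-fold lower number from compound 1 to compound 4 (0.35 log units; beyond the scatter) and this step is beyond the scatter but modest. Nothing available explains these results. Going by these compounds, whether a piperidin-1-yl ring or a carboxylic acid at this place would shift the number more stays open. So does whether any group here can bring it far lower.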